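Methoxy on the fused core: a guess from one step

A few compounds are considered here, and "the series" means these few. Any claim that something is new, unique, unknown or untested is made for them only; others in the source may bear on it.

Measured so far:
- compound 1 `O=C(Nc1ccc(-n2ncc3c(Cl)cccc32)cc1)Nc1ccc(Cl)c(C(F)(F)F)c1`: 1300 nM
- compound 2 `O=C(Nc1ccc(-n2ncc3ccccc32)cc1)Nc1ccc(Cl)c(C(F)(F)F)c1`: 5500 nM

Both compounds were tested in a functional assay on NCI-H460 cells (Homo sapiens) for cytotoxicity, read by MTT assay, with a stated time of 72 h; on this read-out lower numbers stand for stronger inhibition and higher numbers for weaker inhibition. Compound 2 has the highest number of the two; its nearest neighbour is compound 1, and the change between them is a 4.2-fold higher number from compound 1 to compound 2 (0.63 log units; beyond the scatter), which came from replacing a chloro group on an aromatic carbon with hydrogen.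

Compound 3 `COc1cccc2c1cnn2-c1ccc(NC(=O)Nc2ccc(Cl)c(C(F)(F)F)c2)cc1` is not yet measured. It differs from compound 2 by methoxy in place of hydrogen on an aromatic carbon, a methoxy group in place of hydrogen on an aromatic carbon. Within the data shown here, the only step that bears on it is the one from compound 1 to compound 2, where removing a substituent from an aromatic carbon of the shared core gave a modest rise in the number; placing a substituent back on that core is therefore expected to lower the number modestly in this assay. Compound 3 is expected to give about 2500 nM, with a likely range from 900 nM to 7000 nM, which corresponds to an estimated step of a 2.2-fold lower number from compound 2 to compound 3 (0.34 log units; beyond the scatter).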

Compound 3, half-maximal inhibitory concentration: 2200 nM
Beside the measured number, compound 3's estimate is 1.1-fold (0.06 log units) above it; low and high end bracket the measured number.
By their numbers in this assay, from the lowest: compounds 1 and 3 (each within the scatter of the next); then compound 2.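

Among these compounds, compound 3 shows that chloro is not the only group on this aromatic carbon that goes with a lower number than hydrogen: in this assay, methoxy in place of hydrogen gives a 2.5-fold lower number from compound 2 to compound 3 (0.40 log units; beyond the scatter) on the shared core. Exchanging one substituent for the other gives a 1.7-fold higher number from compound 1 to compound 3 (0.23 log units; within the scatter), so this assay does not tell methoxy and chloro apart at this position. Nothing available explains why either group lowers the number compared with hydrogen.

From the compounds shown here alone, it remains open whether an amine, a carboxylic acid or a longer chain such as ethoxy on this same carbon would also go with a lower number than hydrogen. Going by these compounds, it is equally open whether methoxy on a different aromatic carbon of the shared core would give a similar step.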